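Shortening a Branched Amine Chain on a Cyclohexene Core

The source may report more compounds than this note shows. Statements on the series, on what has been measured and on what is new or still open speak of the compounds shown alone.

Of the compounds shown here, two sharing an amino-cyclohexenetriol core have been measured in an assay for inhibition of beta-galactosidase (Homo sapiens), read by fluorescence, with a stated time of 30 min, at pH 4.5; a higher number here means a weaker inhibitor, a lower number a stronger inhibitor. Compound 1 `CCCCCCCCN[C@@H]1C=C[C@H](O)[C@H](O)[C@H]1O` carries an octyl chain on the amine nitrogen and gives 120000 nM. Compound 2 `CCC(CC)CN[C@@H]1C=C[C@H](O)[C@H](O)[C@H]1O` carries a branched chain instead and gives 15000 nM, the lowest of the two numbers, with compound 1 standing well above it, beyond the usual scatter.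

Compound 3 `CC(C)CCN[C@@H]1C=C[C@H](O)[C@H](O)[C@H]1O` is the next candidate. It differs from compound 2 in one place: isobutyl in place of pentan-3-yl on a saturated chain carbon bound to an amine nitrogen. Within the data shown here, no measured pair shows this exact change, so the size of the step is uncertain. The change removes one carbon and moves the branch point, keeping a short chain rather than returning to the long one of compound 1. The expectation is a modest rise, a 2.0-fold higher number from compound 2 to compound 3 (0.30 log units; within the scatter), perhaps beyond the scatter. Compound 3 is therefore estimated at 30000 nM, within a range of 10000 nM to 100000 nM.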

Compound 3, half-maximal inhibitory concentration: 28000 nM
Estimate against measurement, compound 3: 1.1-fold (0.03 log units) above, within the range that was stated.
By their numbers in this assay, from the lowest: compounds 2 and 3 (each within the scatter of the next); then compound 1.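

In this assay the swap of pentan-3-yl for isobutyl amounts to a 1.9-fold higher number from compound 2 to compound 3 (0.27 log units; within the scatter) and cannot be told apart from the usual scatter: at this position, losing one carbon and moving the branch point leaves no change that this measurement can detect. The comparison with the long chain reads differently, as isopropyl in place of hexyl on a saturated chain carbon gives a 4.3-fold lower number from compound 1 to compound 3 (0.63 log units; beyond the scatter) and this modest step lies beyond the scatter. A second short branched chain, and not only the one in compound 2, therefore gives a lower number than the octyl chain of compound 1, and no compound shown goes against that.

Each short chain here is also branched, so the compounds shown leave open whether length or branching matters, a question that a straight pentyl chain would help to separate. Nothing measured here explains why these chains give these numbers.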